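The source may report more compounds than this note shows. Statements on the series, on what has been measured and on what is new or still open speak of the compounds shown alone.

Compound 1 `COc1ccc(-c2nc3cnccn3c2Nc2cc(OC)c(OC)c(OC)c2)cc1O`: 50000 nM
Compound 2 `COc1ccc(Nc2c(-c3ccc(F)cc3)nc3cnccn23)cc1`: 72000 nM

In an ADME assay on Vero cells (Chlorocebus sabaeus) for cytotoxicity, read by MTT assay (on this read-out higher numbers stand for lower toxicity in this test and lower numbers for higher toxicity in this test), compound 1 gives 50000 nM and compound 2 gives 72000 nM. These two values lie within the usual scatter of repeated measurements, so compound 2 stands level with compound 1 and neither can be ranked above the other.

Compound 3 `COc1ccc(Nc2c(-c3ccc(Cl)cc3)nc3cnccn23)cc1` has not yet been measured. It keeps the frame of compound 2 but carries chloro in place of fluoro on an aromatic carbon, para to a large group: chloro in place of fluoro on an aromatic carbon. The same difference can be read as 4-fluorophenyl to 4-chlorophenyl.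

Within the data shown here, no measured pair differs in one place only, so the data give no direct guide to this swap. Still, compound 1 differs from compound 2 in more than one place, and the two values stay within the scatter. The expected result is no change beyond the scatter in this assay, with a slight lean towards a lower number, and the estimated step is a 1.2-fold lower number from compound 2 to compound 3 (0.08 log units; within the scatter). For compound 3 the estimate is 60000 nM, with an expected range from 28000 nM to 120000 nM.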

Compound 3, concentration lethal to 50% of the cells: 45000 nM
Compound 3: the middle estimate sits 1.3-fold (0.12 log units) above what was measured; the range from low to high includes it.
By their numbers in this assay, from the lowest: compounds 3, 1 and 2 (each within the scatter of the next).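

Among these compounds, this is the first pair in the set that differs in one place only, so the swap on the aromatic carbon, para to a large group, can now be read directly: in this assay, chloro in place of fluoro gives a 1.6-fold lower number from compound 2 to compound 3 (0.20 log units; within the scatter). That step lies within the scatter, so at this position the test cannot tell 4-fluorophenyl from 4-chlorophenyl, even though one heavy atom has been exchanged for another of a different element. No supporting data bear on why the two groups read alike, so the result stands here as an observation without an explanation.

Fluoro and chloro are the only two groups shown on this aromatic carbon, so it remains open whether a quite different group there, such as an amine or a carboxylic acid, would move the number beyond the scatter. On these data alone, it also remains open whether this swap would read the same way on another frame, or in any test other than this one on Vero cells.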